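The source may report more compounds than this note shows. Statements on the series, on what has been measured and on what is new or still open speak of the compounds shown alone.

Measured compounds in a functional assay on CHO-K1 cells with Glucose-dependent insulinotropic receptor (Homo sapiens) as the target, read by a luciferase reporter, with a stated time of 5 h; on this read-out higher numbers stand for larger maximal responses and lower numbers for smaller maximal responses:
compound 1, `CC(C)OC(=O)N1CCC(Oc2cccc3c2CCN3c2ccc(S(C)(=O)=O)cc2)CC1`, 70%
compound 2, `CCOC(=O)N1CCC(Oc2ncnc3c2CCN3c2ccc(S(C)(=O)=O)cc2F)CC1`, 135%
compound 3, `CS(=O)(=O)c1ccc(N2CCc3c(OC4CCN(C(=O)OCCF)CC4)ncnc32)c(F)c1`, 86%

In this assay compound 3 stands second highest of the three. Its nearest neighbour is compound 1, whose 70% lies beyond the scatter from it; the furthest is compound 2, whose 135% also lies beyond the scatter. For the measured compounds named here, the only step at the group on the amine nitrogen in a ring is a number 49 percentage points lower from compound 2 to compound 3 (beyond the scatter), a large drop for fluoro in place of hydrogen on a saturated chain carbon, two bonds along the chain from an oxygen next to a carbonyl group.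

Compound 4, `CC(C)c1noc(N2CCC(Oc3ncnc4c3CCN4c3ccc(S(C)(=O)=O)cc3F)CC2)n1`, is not yet measured. It differs from compound 3 by 3-isopropyl-1,2,4-oxadiazol-5-yl in place of (2-fluoroethoxy)carbonyl on an amine nitrogen in a ring. Going by the values given here, no measured step exchanges the whole (2-fluoroethoxy)carbonyl for an aromatic ring, so nothing bears directly on this change; the step of a number 49 percentage points lower from compound 2 to compound 3 (beyond the scatter) shows only that a small change at this place can shift the maximal response a great deal. A shift in either direction beyond the scatter is therefore possible, and the estimate is kept wide. The expected step is a number 4 percentage points higher from compound 3 to compound 4 (within the scatter). Compound 4 is estimated at 90%, between 55% and 130%.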

Compound 4, largest response reached (reported as percent of maximum), in percent of the reference or control that the assay uses: 124%
Compound 4: the middle estimate sits 34 percentage points below what was measured, and the stated range covers the measured number.
By their numbers in this assay, from the lowest: compound 1; then compound 3; then compound 4; then compound 2.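

Working notes: the amine nitrogen in a ring need not carry a carbonyl-linked group to give a high maximal response. In this assay, 3-isopropyl-1,2,4-oxadiazol-5-yl in place of (2-fluoroethoxy)carbonyl gives a number 38 percentage points higher from compound 3 to compound 4 (beyond the scatter), so a five-membered aromatic ring with 3 hetero atoms can stand at this place. Against ethoxycarbonyl the same exchange gives a number 11 percentage points lower from compound 2 to compound 4 (beyond the scatter), a smaller change than the one from the fluorinated group, and the shown data offer no explanation for either step.

On these data alone, whether the response depends on the ring or on its isopropyl group remains open; methyl or cyclopropyl on the same ring would separate the two. Also open, as far as these compounds go, is whether a six-membered aromatic ring such as pyrimidine at this nitrogen would give a comparable maximal response.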